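Changing the Aryl Group on the Amide Nitrogen

A few compounds are considered here, and "the series" means these few. Any claim that something is new, unique, unknown or untested is made for them only; others in the source may bear on it.

For the measured compounds named here, in an ADME assay on BaF3 cells (Mus musculus) for antiproliferative activity, read by CCK-8 assay, with a stated time of 72 h (a lower number here means a stronger inhibitor of growth, a higher number a weaker inhibitor of growth), compound 2 `COc1cccc(NC(=O)CCSc2ccc3c(/C=C/c4ccccn4)n[nH]c3c2)c1` gives 3840 nM as the only true number in this small set. Compound 1 `Cc1cccc(NC(=O)CCSc2ccc3c(/C=C/c4ccccn4)n[nH]c3c2)c1` gives > 10000 nM and that is a limit of the assay. Compound 3 `CN1CCN(c2cccc(NC(=O)CCSc3ccc4c(/C=C/c5ccccn5)n[nH]c4c3)c2)CC1` gives > 10000 nM and that too is a limit. Compound 4 `O=C(CCSc1ccc2c(/C=C/c3ccccn3)n[nH]c2c1)Nc1ccc(Cl)c(C(F)(F)F)c1` places 4-chloro-3-(trifluoromethyl)phenyl on the amide-type nitrogen in place of 3-methoxyphenyl (4-chloro-3-(trifluoromethyl)phenyl in place of 3-methoxyphenyl on an amide-type nitrogen). Two measured steps alter a group on this aromatic ring (an at least 2.6-fold lower number from compound 1 to compound 2 (0.41 log units; beyond the scatter); an at least 2.6-fold higher number from compound 2 to compound 3 (0.41 log units; beyond the scatter)). Both are at least modest, and they run in opposite directions. Neither tests the entering group, so any forecast is loose. The expected change is a 2.6-fold lower number from compound 2 to compound 4 (0.41 log units; beyond the scatter) in this assay with its direction uncertain. For compound 4 the estimate is 1500 nM with 150 nM to 10000 nM as the expected range.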

Compound 4, concentration for 50% growth inhibition: > 10000 nM
Compound 4: a limit, no number; the forecaster's own chance of this, stated with the estimate: 25%; at least 6.6-fold (0.82 log units) between middle value and limit.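

In this assay, 4-chloro-3-(trifluoromethyl)phenyl in place of 3-methoxyphenyl on the amide-type nitrogen gives an at least 2.6-fold higher number from compound 2 to compound 4 (0.41 log units; beyond the scatter). This shows that a larger ring carrying chlorine and trifluoromethyl does not improve on the 3-methoxyphenyl ring, which alone still gives a true number here. The step from compound 1 to compound 4 cannot be read, since both values are limits and not numbers: the limit of > 10000 nM in this assay, at which 3 of the 4 values shown sit.

The compounds shown leave open how a plain phenyl ring, or a ring carrying only chlorine, would behave on this nitrogen. They also leave open what a ring bearing a carboxylic acid would give.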